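A few compounds are considered here, and "the series" means these few. Any claim that something is new, unique, unknown or untested is made for them only; others in the source may bear on it.

Compound 1 `CCCc1ccccc1OS(=O)(=O)c1cccc(NC(=O)NCCCCl)c1`: 15000 nM
Compound 2 `Cc1ccccc1NS(=O)(=O)c1cccc(NC(=O)NCCCCl)c1`: 60000 nM
Compound 3 `CCCc1ccccc1OS(=O)(=O)c1cccc(NC(=O)NCC)c1`: 25000 nM

All three were tested in a functional assay on M21 cells (Homo sapiens) for cytotoxicity, read by sulforhodamine B assay, with a stated time of 48 h; a higher number here means a weaker inhibitor, a lower number a stronger inhibitor. Compound 3 differs from compound 1 only by hydrogen in place of chloromethyl on a saturated chain carbon, two bonds along the chain from an amide-type nitrogen, and that single change gave a 1.7-fold higher number from compound 1 to compound 3 (0.22 log units; within the scatter). Compound 2 rests on a different core from compound 1; the difference between the two cores is not broken down here. Among the three, compound 2 gives the highest number, and its gaps to the other two lie beyond the scatter.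

Compound 4 `CCNC(=O)Nc1cccc(S(=O)(=O)Nc2ccccc2C)c1` is the not yet measured partner of compound 2. It differs from compound 2 by hydrogen in place of chloromethyl on a saturated chain carbon, two bonds along the chain from an amide-type nitrogen, the same change as from compound 1 to compound 3, at the same place. The step from compound 2 to compound 4 is expected to be small, a 1.5-fold higher number from compound 2 to compound 4 (0.18 log units; within the scatter), because a 1.7-fold higher number from compound 1 to compound 3 (0.22 log units; within the scatter) stayed within the scatter. For compound 4 the expected value is 90000 nM.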

Compound 4, half-maximal inhibitory concentration: 131000 nM
Compound 4: middle estimate off by 1.5-fold (0.16 log units), on the low side; measured number inside the range.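

Putting hydrogen in place of chloromethyl, which turns the 3-chloropropyl chain into ethyl, gave a 2.2-fold higher number from compound 2 to compound 4 (0.34 log units; beyond the scatter) in this assay. Set beside the earlier step on the other core, this step is not clearly different in size: the same change on two cores in this assay, a 1.7-fold higher number (0.22 log units; within the scatter) from compound 1 to compound 3 and a 2.2-fold higher number (0.34 log units; beyond the scatter) from compound 2 to compound 4, 1.3-fold (0.12 log units) apart, within the scatter of two such steps. For the compounds shown here, the change therefore carried across these two cores with a similar result, although only this new step lies beyond the scatter, and two pairs say nothing about other cores or about what lies behind the step.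

The compounds shown leave open how an amine, a carboxylic acid or a longer chain at this position would compare with ethyl. They also do not separate the individual differences between the two cores.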